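Amine swap at the chain carbon: compound 2 to compound 3

The source may report more compounds than this note shows. Statements on the series, on what has been measured and on what is new or still open speak of the compounds shown alone.

Measured so far:
compound 1 `CCCCCCCCCCCCCC[C@H](OCOC)[C@H](CO)NC(=O)OC(C)(C)C`: 10.2%
compound 2 `CCCCCCCCCCCCCC[C@H](OCOC)[C@H](CN(CCCC)CCCC)NC(=O)OC(C)(C)C`: 27.1%

In a functional assay on MCF7 cells (Homo sapiens) for antiproliferative activity, read by sulforhodamine B assay, with a stated time of 48 h, tested at 10 uM (a lower number here means less inhibition, a higher number more inhibition at the concentration tested (going by the name of the read-out)), compound 1 gives 10.2% and compound 2 gives 27.1%. Compound 2 stands highest of the two numbers, its nearest neighbour being compound 1, the step being a number 16.9 percentage points higher from compound 1 to compound 2 (beyond the scatter).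

Compound 3 `CCCCCCCCCCCCCC[C@H](OCOC)[C@H](CN1CCN(C)CC1)NC(=O)OC(C)(C)C` differs from compound 2 by 4-methylpiperazin-1-yl in place of dibutylamino on a saturated chain carbon, two bonds along the chain from an amide-type nitrogen. Within the data shown here, the one measured step, a number 16.9 percentage points higher from compound 1 to compound 2 (beyond the scatter), touches the same place, yet it replaced hydroxy with dibutylamino; no measured step compares one amino group with another, so it bears on the change only loosely. Because that step is a number 16.9 percentage points higher from compound 1 to compound 2 (beyond the scatter), the amine at this place matters, but the size of a swap between two amines is open. A step within the scatter, or a small one, is expected for a number 5.1 percentage points lower from compound 2 to compound 3 (within the scatter). Compound 3 is estimated at 22%, within 8% to 40%.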

Compound 3, a percentage reported as inhibition, at one concentration (the size of the read-out at that concentration, not a potency): 28%
Compound 3: the middle estimate sits 6 percentage points below what was measured, and the stated range covers the measured number.
By their numbers in this assay, from the lowest: compound 1; then compounds 2 and 3 (each within the scatter of the next).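

In this assay, among these compounds, the first comparison of two amines at this place gives a number 0.9 percentage points higher from compound 2 to compound 3 (within the scatter), so 4-methylpiperazin-1-yl, with its six-membered non-aromatic ring, and open-chain dibutylamino cannot be told apart here. Replacing hydroxy with an amine now has a second case, a number 17.8 percentage points higher from compound 1 to compound 3 (beyond the scatter), which shows that the rise seen with a number 16.9 percentage points higher from compound 1 to compound 2 (beyond the scatter) is not confined to dibutylamino, though the pattern rests on these two amines alone. No information is available on why the two amines read alike.

Going by these compounds, whether piperidin-1-yl, which lacks the second ring nitrogen, or a smaller amine such as dimethylamino would match compound 2 and compound 3 remains open. Also open, on these data alone, is how a primary amine or a carboxylic acid at this place would read.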